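Acetyl on the amine nitrogen of compound 2

The compounds below may be only part of what the source reports. "The series", "measured", "known", "first", "only" and "open" are said of these compounds alone.

In an ADME assay on liver (Rattus norvegicus) for metabolic stability, read by LC-MS, using S9 fraction, with a stated time of 30 min, tested at 5 uM, in the presence of a further agent that is not named here (on this read-out higher numbers stand for fast clearance and lower numbers for slow clearance), compound 1 (`O/N=C(\Nc1ccc(F)c(Br)c1)c1nonc1NCc1ccccc1`) gives (35 mL/min/kg) and compound 2 (`NCCNc1nonc1/C(=N/O)Nc1ccc(F)c(Br)c1`) gives (18.3 mL/min/kg), so compound 2 stands within the scatter of compound 1. Compound 3 (`CC(=O)NCCNc1nonc1/C(=N/O)Nc1ccc(F)c(Br)c1`) carries acetyl in place of hydrogen on an amine nitrogen, which turns 2-aminoethyl into 2-acetamidoethyl. Going by the values given here, only one measured step bears on this change (a 1.9-fold lower number from compound 1 to compound 2 (0.28 log units; within the scatter)). That step places aminomethyl in place of phenyl on a saturated chain carbon bound to a nitrogen on an aromatic ring, and it stays within the scatter. No acetyl change has been measured, so the data give no direction. The expected step (a 1.2-fold higher number from compound 2 to compound 3 (0.08 log units; within the scatter)) is therefore none beyond the scatter. In this assay compound 3 is estimated at (22 mL/min/kg), with an expected range from (11 mL/min/kg) to (42 mL/min/kg).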

Compound 3, clearance: 15 mL/min/kg
For compound 3 the middle estimate is 1.5-fold (0.17 log units) above the measured one, within the range that was stated.
By their numbers in this assay, from the lowest: compounds 3, 2 and 1 (each within the scatter of the next, the first and the last beyond it).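

Acetyl in place of hydrogen on this amine nitrogen, turning 2-aminoethyl into 2-acetamidoethyl, gives no readable shift in this assay, with a 1.2-fold lower number from compound 2 to compound 3 (0.09 log units; within the scatter). The change of side chain now gives the first separation beyond the scatter in the series, though only a modest one, with a 2.3-fold lower number from compound 1 to compound 3 (0.37 log units; beyond the scatter). No measurement shown accounts for either step.

As far as these compounds go, it remains open how a methanesulfonyl group on the same amine nitrogen, or a carboxylic acid or a longer chain in place of 2-acetamidoethyl, would read in this assay. With acetyl the only acyl group shown, it also remains open whether a larger one, such as benzoyl, would stay within the scatter of compound 2.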